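Lengthening the Benzylamine Chain on Two Adenosine Cores

A few compounds are considered here, and "the series" means these few. Any claim that something is new, unique, unknown or untested is made for them only; others in the source may bear on it.

Compound 1 `CCCn1c(Br)nc2c(N)nc(NCc3ccccc3)nc21`: 1740 nM
Compound 2 `CCCn1c(Br)nc2c(N)nc(NCCCc3ccccc3)nc21`: 6300 nM
Compound 3 `CCCn1c(-c2ccco2)nc2c(NCc3ccccc3)ncnc21`: 1760 nM

These values come from a functional assay on CHO cells for antagonist activity at adenosine receptor A2b (Homo sapiens); on this read-out lower numbers stand for stronger inhibition and higher numbers for weaker inhibition. Compound 1 and compound 2 differ in one place: phenethyl in place of phenyl on a saturated chain carbon bound to a nitrogen on an aromatic ring. That change produced a 3.6-fold higher number from compound 1 to compound 2 (0.56 log units; beyond the scatter). Compound 3 carries the same side chain as compound 1 but a different core; the difference between the two cores is not broken down here. In this assay compound 3 and compound 1 give numbers within the usual scatter of one another.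

Compound 4 `CCCn1c(-c2ccco2)nc2c(NCCCc3ccccc3)ncnc21` has not yet been measured. It differs from compound 3 in one place: phenethyl in place of phenyl on a saturated chain carbon bound to a nitrogen on an aromatic ring, the same change as between compound 1 and compound 2. Because that earlier change gave a 3.6-fold higher number from compound 1 to compound 2 (0.56 log units; beyond the scatter), a step of similar size is expected for compound 4: a 3.1-fold higher number from compound 3 to compound 4 (0.49 log units; beyond the scatter). Compound 4 is therefore estimated at 5500 nM, between 2000 nM and 15000 nM.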

Compound 4, inhibition constant: 1870 nM
Estimate against measurement, compound 4: 2.9-fold (0.47 log units) above; measured number below the stated range.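

Putting phenethyl in place of phenyl on the core of compound 3 gave a 1.1-fold higher number from compound 3 to compound 4 (0.03 log units; within the scatter). The change therefore did not carry over at the same size from one core to the other in this assay: the same change on two cores in this assay, a 3.6-fold higher number (0.56 log units; beyond the scatter) from compound 1 to compound 2 and a 1.1-fold higher number (0.03 log units; within the scatter) from compound 3 to compound 4, 3.4-fold (0.53 log units) apart, beyond the scatter of two such steps

This shows that, for these two pairs, the size of the step depends on the core, but it does not show which part of the core matters, as the two cores differ in more than one place. Two pairs also make no general rule for the series.

The compounds shown leave open how each core would respond to a longer chain, or to an amine at the end of the chain in place of the phenyl ring. For the compounds shown here, they also leave open whether a core carrying only one of the two core differences would behave like the core of compound 1 or like that of compound 3.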